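Spiro-fused amine series: from amide to pyrrolidinylethyl amine

The compounds below may be only part of what the source reports. "The series", "measured", "known", "first", "only" and "open" are said of these compounds alone.

The three measured compounds share a spiro-fused core carrying two phenyl groups. Compound 1 `c1ccc(C2CC3(N4CCCC4)CC(NCN4CCCC4)C2C(c2ccccc2)C3)cc1` gives 30600 nM in an ADME assay on L6 cells (Rattus norvegicus) for cytotoxicity; on this read-out lower numbers stand for stronger inhibition and higher numbers for weaker inhibition. Compound 2 `CN1CCN(CCC(=O)N2CCC3(N4CCCC4)CC(c4ccccc4)C2C(c2ccccc2)C3)CC1` gives 75400 nM in this assay, and compound 3 `CN1CCN(CCC(=O)NC2CC3(N4CCCCC4)CC(c4ccccc4)C2C(c2ccccc2)C3)CC1` gives 61100 nM. The number for compound 3 falls between those of compound 1 and compound 2, and all three values lie within the usual scatter of one another, so no ordering among them can be claimed.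

Compound 4 `c1ccc(C2CC3(N4CCCCC4)CC(NCCN4CCCC4)C2C(c2ccccc2)C3)cc1` is not yet measured. It differs from compound 3 in one place: 2-(pyrrolidin-1-yl)ethyl in place of (2-(4-methylpiperazin-1-yl)ethyl)carbonyl on an amine nitrogen. Compound 1 carries a related basic side chain on the same amine nitrogen and shows 30600 nM, a value that, like those of compound 2 and compound 3, sits within the scatter of the others. From compound 3 to compound 4 the step is therefore expected to be a 1.9-fold lower number from compound 3 to compound 4 (0.28 log units; within the scatter), toward a somewhat lower number but not clearly beyond the scatter. Compound 4 is estimated at 32000 nM, with a range from 14000 nM to 72000 nM.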

Compound 4, half-maximal inhibitory concentration: 27000 nM
For compound 4 the middle estimate is 1.2-fold (0.07 log units) above the measured one; the range from low to high includes it.
By their numbers in this assay, from the lowest: compounds 4, 1, 3 and 2 (each within the scatter of the next, the first and the last beyond it).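

Going by these compounds alone, on an amine nitrogen whose other neighbour is a saturated ring carbon, 2-(pyrrolidin-1-yl)ethyl in place of (2-(4-methylpiperazin-1-yl)ethyl)carbonyl gives the first single-place step that can be read in this assay: a 2.3-fold lower number from compound 3 to compound 4 (0.35 log units; beyond the scatter). The change takes away the carbonyl and the six-membered ring together, so the step cannot be assigned to either part alone. Nothing at hand explains the step.

The compounds shown leave open how a 2-(4-methylpiperazin-1-yl)ethyl group without the carbonyl, or a (2-(pyrrolidin-1-yl)ethyl)carbonyl group, would read on this amine nitrogen, and only such a pair could separate the two parts of the change. Also open, on these data alone, is how a morpholine ring or a longer chain in this place would read in this assay.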